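The source may report more compounds than this note shows. Statements on the series, on what has been measured and on what is new or still open speak of the compounds shown alone.

Compound 1 `O=C(COc1ccc(C(=O)/C=C/c2ccc(F)c(F)c2)cc1)N[C@H]1CCOC1=O` and compound 4 `O=C(COc1ccc(C(=O)/C=C/c2ccc(Br)cc2)cc1)N[C@H]1CCOC1=O` share one core and differ in a single place. In a functional assay on MCF7 cells (Homo sapiens) for antiproliferative activity, read by MTT assay, with a stated time of 72 h (a higher number here means a weaker inhibitor, a lower number a stronger inhibitor), compound 1 gives no number but only a limit of the assay, > 64000 nM. Compound 2 `O=C1OCC[C@@H]1NC(=S)SCCOc1ccccc1` also reaches only a limit in this assay, > 64000 nM. Compound 3 `CCOc1ccccc1OCCSC(=S)N[C@H]1CCOC1=O` likewise stands at a limit in this assay, > 64000 nM. Within the data shown here, the one measured step between neighbours, a step that the two limits leave unreadable from compound 2 to compound 3, cannot be sized because the limit of > 64000 nM in this assay, at which 3 of the 3 values shown sit, holds both of its ends. So compound 1 stands where every measured compound stands, at the limit, with nothing read below it.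

The change from compound 1 to compound 4 is 4-bromophenyl in place of 3,4-difluorophenyl on a double-bonded chain carbon bound to a double-bonded chain carbon. Among the measured compounds shown here, neither compound 2 nor compound 3 carries this change, so no measured step bears on it, and the one step that exists is itself unreadable. The expected step that the limit leaves unreadable from compound 1 to compound 4 therefore rests only on compound 1 sitting at its limit > 64000 nM. Compound 4 is estimated at about 80000 nM, from 25000 nM to 250000 nM, most likely reported again only as a limit.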

Compound 4, half-maximal inhibitory concentration: > 64000 nM
Compound 4: no number, only a limit; the forecaster's own chance of this, stated with the estimate: 75%; the middle value does not contradict the limit.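

In this assay compound 4 gives only a limit, as compound 1 does, so the step between them cannot be read: the limit of > 64000 nM in this assay, at which 4 of the 4 values shown sit. The compounds shown leave open how far each lies beyond that limit, and so whether 4-bromophenyl and 3,4-difluorophenyl differ at all.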